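This account rests on a few compounds, and the source may have more. Where it says the series, first, only, none or still open, it means among the compounds named here.

Measured so far in an assay on isolated protein for inhibition of Alpha glucosidase (Homo sapiens), with stated times of 5 min and 15 min; a higher number here means a weaker inhibitor, a lower number a stronger inhibitor:
Compound 1 `O=C1/C(=C/c2ccccc2)CCC/C1=C\c1cccc(O)c1` gives 28400 nM.
Compound 2 `O=C1/C(=C/c2ccccc2)CCC/C1=C\c1ccc(O)c(O)c1` gives 20300 nM.
Compound 3 `O=C(/C=C(O)/C=C/c1cccc(O)c1)c1cc(Cl)ccc1O` gives 36400 nM.

Compound 1 and compound 2 share one core, and compound 2 differs from compound 1 in a single place: hydroxy in place of hydrogen on an aromatic carbon. That change gave a 1.4-fold lower number from compound 1 to compound 2 (0.15 log units; within the scatter), so the two numbers cannot be told apart with confidence.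

Compound 3 is built on another core; how its core differs from the core of compound 1 is not broken down here. Its number lies closest to that of compound 1 and furthest from that of compound 2, yet both gaps stay within the scatter, so no ranking of the three compounds can be read from these numbers.

Compound 4 `O=C(/C=C(O)/C=C/c1ccc(O)c(O)c1)c1cc(Cl)ccc1O` has not yet been measured. It arises from compound 3 by one change: hydroxy in place of hydrogen on an aromatic carbon. This is the same change that leads from compound 1 to compound 2, made here on the core of compound 3; the surroundings of the place are described in the same words in both cases, and the change appears in two pairs among the compounds shown. The expectation for compound 4 rests on this one earlier pair. Because that pair gave a 1.4-fold lower number from compound 1 to compound 2 (0.15 log units; within the scatter), a step of about the same small size is expected, a 1.4-fold lower number from compound 3 to compound 4 (0.15 log units; within the scatter). Compound 4 is therefore estimated at 26000 nM in this assay, with most repeat measurements expected between 12000 nM and 60000 nM.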

Compound 4, half-maximal inhibitory concentration: 15100 nM
Compound 4: the middle estimate sits 1.7-fold (0.24 log units) above what was measured; the range from low to high includes it.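

In this assay, hydroxy in place of hydrogen on an aromatic carbon gave a 2.4-fold lower number from compound 3 to compound 4 (0.38 log units; beyond the scatter), a modest step on the core of compound 3. Set beside the earlier pair, this step cannot be told apart from the one on the core of compound 1, so the change can be said to carry over between these two cores within what such measurements can resolve: the same change on two cores in this assay, a 1.4-fold lower number (0.15 log units; within the scatter) from compound 1 to compound 2 and a 2.4-fold lower number (0.38 log units; beyond the scatter) from compound 3 to compound 4, 1.7-fold (0.24 log units) apart, within the scatter of two such steps. This does not show that the two steps are truly equal, since only one of them stands clear of the scatter, and two pairs are too few to make a rule for any further core.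

The compounds shown cover only one swap, hydroxy for hydrogen, at a place ortho to a hydroxy group and para to a large group, so they leave open whether a hydroxy group elsewhere on the ring would give a step of similar size. They also leave open what a different group at this same place, such as a methoxy group, an amine or a carboxylic acid, would do to the number on either core.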